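Swapping the Ring-Neighbour Group on a Pyridine Core

The compounds below may be only part of what the source reports. "The series", "measured", "known", "first", "only" and "open" are said of these compounds alone.

Compound 1 `CC(C(=O)NCc1ccc(C(C)(C)C)nc1N1CCCCCC1)c1ccc(NS(C)(=O)=O)c(F)c1`: 0.9 nM
Compound 2 `CCOCCOc1nc(C(C)(C)C)ccc1CNC(=O)C(C)c1ccc(NS(C)(=O)=O)c(F)c1`: 23.9 nM

In an assay on cells for antagonist activity at transient receptor potential cation channel subfamily V member 1 (Homo sapiens), read by FLIPR and calcium flux, with a stated time of 6 min (on this read-out higher numbers stand for weaker inhibition and lower numbers for stronger inhibition), compound 2 gives 23.9 nM, the highest of the two numbers; its nearest neighbour is compound 1 at 0.9 nM. Compound 3 `CC(C(=O)NCc1ccc(C(C)(C)C)nc1SCc1ccccc1)c1ccc(NS(C)(=O)=O)c(F)c1` differs from compound 2 by benzylsulfanyl in place of 2-ethoxyethoxy on an aromatic carbon. Within the data shown here, only one measured step bears on this position: a 27-fold higher number from compound 1 to compound 2 (1.42 log units; beyond the scatter), a large change showing that what sits here matters greatly. Since the group in compound 3 is again a large one rather than the chain of compound 2, a lower number is expected, with a 4.8-fold lower number from compound 2 to compound 3 (0.68 log units; beyond the scatter). Compound 3 is estimated at 5 nM, within 1.2 nM to 25 nM.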

Compound 3, inhibition constant: 4 nM
Estimate against measurement, compound 3: 1.3-fold (0.10 log units) above, and the stated range covers the measured number.
By their numbers in this assay, from the lowest: compound 1; then compound 3; then compound 2.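

Benzylsulfanyl wins back much of what 2-ethoxyethoxy lost, with a 6.0-fold lower number from compound 2 to compound 3 (0.78 log units; beyond the scatter) in this assay for this swap. It still falls short of azepan-1-yl, with a 4.4-fold higher number from compound 1 to compound 3 (0.65 log units; beyond the scatter) left over, so this position separates all three groups, and both groups carrying a ring give lower numbers than the open chain. No measurement here explains these differences.

From the compounds shown here alone, it remains open whether a smaller ring such as piperidin-1-yl would match azepan-1-yl. Benzyloxy, with oxygen in place of sulfur, could show whether the sulfur matters to the gain.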